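A few compounds are considered here, and "the series" means these few. Any claim that something is new, unique, unknown or untested is made for them only; others in the source may bear on it.

Measured in a functional assay on HeLa cells (Homo sapiens) for antiproliferative activity, read by MTT assay, with a stated time of 24 h; a higher number here means a weaker inhibitor, a lower number a stronger inhibitor:
- compound 1 `Cc1ccc(-c2nn(-c3ccccc3)cc2-c2nc3ccccc3n2S(=O)(=O)c2ccccc2)cc1`: 820 nM
- compound 2 `Cc1ccc(-c2nn(-c3ccccc3)cc2-c2nc3ccccc3n2S(=O)(=O)c2ccc(Cl)cc2)cc1`: 4060 nM
- compound 3 `O=S(=O)(c1ccccc1)n1c(-c2cn(-c3ccccc3)nc2-c2ccc(F)cc2)nc2ccccc21`: 680 nM

On these numbers, compound 3 at 680 nM cannot be separated from compound 1 at 820 nM, since the two lie within the scatter of each other. Compound 3 has a lower number than compound 2 at 4060 nM.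

The next compound, compound 4 `O=S(=O)(c1ccc(C(F)(F)F)cc1)n1c(-c2cn(-c3ccccc3)nc2-c2ccc(F)cc2)nc2ccccc21`, is made from compound 3 by one change: trifluoromethyl in place of hydrogen on an aromatic carbon. Trifluoromethyl takes the place of hydrogen on an aromatic carbon, turning phenyl into 4-(trifluoromethyl)phenyl.

Two measured steps can be weighed against this. The nearer guide is chloro in place of hydrogen on the same phenyl, a 5.0-fold higher number from compound 1 to compound 2 (0.69 log units; beyond the scatter), a modest step beyond the scatter. The other, a 1.2-fold lower number from compound 1 to compound 3 (0.08 log units; within the scatter), is fluoro in place of methyl at a different place and stays within the scatter, so it says little here. With only the chloro step as precedent, a modest rise in the number is expected in this assay, though the size is uncertain.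

The expected change is a 3.7-fold higher number from compound 3 to compound 4 (0.57 log units; beyond the scatter).

For compound 4 the estimate is 2500 nM, with an expected range from 600 nM to 8000 nM.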

Compound 4, half-maximal inhibitory concentration: 1430 nM
The estimate for compound 4 lay 1.7-fold (0.24 log units) above the measured number; the measured number falls inside the stated range.
By their numbers in this assay, from the lowest: compounds 3, 1 and 4 (each within the scatter of the next, the first and the last beyond it); then compound 2.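

In this assay, the change from phenyl to 4-(trifluoromethyl)phenyl gives a 2.1-fold higher number from compound 3 to compound 4 (0.32 log units; beyond the scatter), so a group at this place on the compound carrying fluoro also moves the number upward. Before this, the only change on this phenyl was chloro in place of hydrogen on the compound carrying methyl, a 5.0-fold higher number from compound 1 to compound 2 (0.69 log units; beyond the scatter); there are now two such steps, from two different starting compounds, both in the same direction and both beyond the scatter, and no compound shown goes against this. Nothing available here accounts for the rise in either step, and the result gives the direction of the change on this phenyl but no reason for it.

The chloro and trifluoromethyl steps start from different compounds, so the compounds shown cannot say whether the two groups differ in their effect, or whether the step depends on the methyl or fluoro group elsewhere in the molecule. As far as these compounds go, it also remains open whether a methoxy group, an amine or a carboxylic acid in the same place would raise the number too, or whether the unsubstituted phenyl would still give the lowest number of the set.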